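Formyl to aryl imine on the shared core

A few compounds are considered here, and "the series" means these few. Any claim that something is new, unique, unknown or untested is made for them only; others in the source may bear on it.

Three compounds of the series have numbers in a functional assay on SF-268 cells (Homo sapiens) for inhibition, read by sulforhodamine B assay, with a stated time of 72 h; on this read-out higher numbers stand for weaker inhibition and lower numbers for stronger inhibition. Compound 1 `Cc1nc2cc(Br)ccc2nc1Oc1ccc(N)cc1` gives 0.00008 ug/mL. Compound 2 `Cc1nc2cc(Br)ccc2nc1Oc1ccc(/N=C\c2ccc(Cl)cc2)cc1` gives 0.00002 ug/mL. Compound 3 `Cc1nc2cc(Br)ccc2nc1Oc1ccc(C=O)cc1` gives 0.0405 ug/mL, the highest of the three; its nearest neighbour is compound 1, with a 510-fold higher number from compound 1 to compound 3 (2.70 log units; beyond the scatter), and the widest gap is to compound 2, with a 2000-fold higher number from compound 2 to compound 3 (3.31 log units; beyond the scatter).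

Compound 4 `Cc1nc2cc(Br)ccc2nc1Oc1ccc(/C=N\c2ccc(Cl)cc2)cc1` is not yet measured. It differs from compound 3 by a group of 9 heavy atoms (7 carbon, 1 nitrogen, 1 chlorine; one six-membered aromatic ring of carbon only) in place of a group of 2 heavy atoms (1 carbon, 1 oxygen; no ring), on an aromatic carbon. The group that enters is the same nine-heavy-atom group that enters between compound 1 and compound 2, and the group that leaves is the formyl that sits on compound 3.

Going by the values given here, two measured steps bear on this change. The step of a 4.0-fold lower number from compound 1 to compound 2 (0.60 log units; beyond the scatter) shows that attaching this group to the core lowers the number modestly. The step of a 2000-fold higher number from compound 2 to compound 3 (3.31 log units; beyond the scatter) shows that exchanging the group for formyl raises the number strongly; the change here runs in the opposite direction. A large step downward in this assay is therefore expected, beyond the scatter, though the double bond sits the other way round and the exact size is uncertain.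

Compound 4 is expected at 0.0001 ug/mL, within 0.00001 ug/mL to 0.002 ug/mL. The expected step is a 410-fold lower number from compound 3 to compound 4 (2.61 log units; beyond the scatter).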

Compound 4, half-maximal inhibitory concentration: 0.0304 ug/mL
Beside the measured number, compound 4's estimate is 300-fold (2.48 log units) below it, and the stated range ends below it.
By their numbers in this assay, from the lowest: compound 2; then compound 1; then compounds 4 and 3 (each within the scatter of the next).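

In this assay, the group on compound 4 carries the same heavy atoms as the group on compound 2, and the two differ only in which way round the double bond sits, yet the change gives a 1500-fold higher number from compound 2 to compound 4 (3.18 log units; beyond the scatter) and so counts of atoms and rings alone do not set the number at this position. Going by these compounds alone, exchanging formyl for this group gives a 1.3-fold lower number from compound 3 to compound 4 (0.12 log units; within the scatter) with no separation between the two compounds, while a 380-fold higher number from compound 1 to compound 4 (2.58 log units; beyond the scatter) sets compound 4 apart from the amine, so across these four compounds the two with nitrogen on the aromatic carbon, compound 1 and compound 2, have the low numbers and the two with carbon there, compound 3 and compound 4, have the high numbers, with no compound going against this. Nothing measured here explains the contrast between the two imine orientations.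

Open, going by these compounds, is whether nitrogen on the aromatic carbon is enough in itself, which an amide or a methylamine at this place would test, and whether a carboxylic acid or hydroxymethyl behaves like formyl. Also open, on these data alone, is whether the double bond matters in compound 2, which the saturated benzylamine would address, and whether the chlorine on the added ring contributes, which an unsubstituted phenyl or a methoxy in its place would show.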